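A few compounds are considered here, and "the series" means these few. Any claim that something is new, unique, unknown or untested is made for them only; others in the source may bear on it.

Series values in a functional assay on DU-145 cells (Homo sapiens) for antiproliferative activity, read by WST assay, with a stated time of 3 days; on this read-out higher numbers stand for weaker inhibition and lower numbers for stronger inhibition:
Compound 1 `COc1cc(-c2oc3ccccc3c(=O)c2OC(C)C)cc(OC)c1OC`: > 50000 nM (a limit of the assay, not a number)
Compound 2 `CCN(CC)CCCCOc1c(-c2cc(OC)c(OC)c(OC)c2)oc2ccccc2c1=O`: 13300 nM

Among the compounds with values here, compound 2 holds the only actual number in this assay so far, and the one other entry is the limit of compound 1, noted in the limit of > 50000 nM in this assay, at which 1 of the 2 values shown sits. Compound 3 `CCN(CC)CCCCCOc1c(-c2cc(OC)c(OC)c(OC)c2)oc2ccccc2c1=O` is still unmeasured in this assay. Its difference from compound 2 is (diethylamino)methyl in place of diethylamino on a saturated chain carbon, four bonds along the chain from an oxygen on an aromatic ring, which amounts to (diethylamino)methyl in place of diethylamino on a saturated chain carbon, four bonds along the chain from an oxygen on an aromatic ring.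

Within the data shown here, one measured step bears on this: an at least 3.7-fold lower number from compound 1 to compound 2 (0.57 log units; beyond the scatter). That step is a much larger exchange than the present one, and its size is bounded by a limit, so only a small move towards lower numbers is expected, probably not beyond the scatter. The expected change is a 1.5-fold lower number from compound 2 to compound 3 (0.17 log units; within the scatter). For compound 3 the estimate is 9000 nM, with an expected range of 3500 nM to 22000 nM.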

Compound 3, half-maximal inhibitory concentration: 33400 nM
Estimate against measurement, compound 3: 3.7-fold (0.57 log units) below; the whole stated range lies below it.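

In this assay, going from 4-(diethylamino)butyl to 5-(diethylamino)pentyl on the oxygen moves the number upward: a 2.5-fold higher number from compound 2 to compound 3 (0.40 log units; beyond the scatter). Chain length at this position therefore matters, and across these two chains the longer one does not give the lower number. With the pentyl chain, the step from isopropyl reads only an at least 1.4-fold lower number from compound 1 to compound 3 (0.17 log units; that floor lies within the scatter), and it is bounded on one side by a limit of the assay, not a number: the limit of > 50000 nM in this assay, at which 1 of the 3 values shown sits.

As far as these compounds go, two chain lengths cannot show whether 4-(diethylamino)butyl marks a best length, so the shorter 3-(diethylamino)propyl and 2-(diethylamino)ethyl chains remain open. Also open, from the compounds shown here alone, is whether another amine at the chain end, such as pyrrolidine or morpholine, would shift the number at the same chain length.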